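This account rests on a few compounds, and the source may have more. Where it says the series, first, only, none or still open, it means among the compounds named here.

Three compounds have been measured in a physicochemical assay for solubility, read by HPLC; on this read-out higher numbers stand for higher solubility and lower numbers for lower solubility:

Compound 1 `CC(=O)NC[C@H]1CN(c2ccc(OC[C@H](O)CNc3cc(C(F)(F)F)cc(C(F)(F)F)c3)c(F)c2)C(=O)O1` gives 22000 nM
Compound 2 `CC(=O)NC[C@H]1CN(c2ccc(OC[C@H](O)CNc3ccccn3)c(F)c2)C(=O)O1` gives 35100000 nM
Compound 3 `COc1ccc(N2C[C@H](COc3ccc(N4C[C@H](CNC(C)=O)OC4=O)cc3F)OC2=O)cc1` gives 211000 nM

Compound 2 gives the highest of the three numbers; compound 3 lies nearest to it, and compound 1 furthest, and both gaps reach beyond the usual scatter. Compound 4 `CC(=O)NC[C@H]1CN(c2ccc(OC[C@@H]3CNC(=O)O3)c(F)c2)C(=O)O1` has not yet been measured in this assay. It differs from compound 2 in one place: 2-oxo-1,3-oxazolidin-5-yl in place of 1-hydroxy-2-((pyridin-2-yl)amino)ethyl on a saturated chain carbon bound to an oxygen on an aromatic ring. The change removes a larger group and puts a smaller ring in its place on the same saturated chain carbon. From compound 2 alone, which stands far above the other two, a clear downward step is expected, estimated as a 35-fold lower number from compound 2 to compound 4 (1.55 log units; beyond the scatter). Compound 4 is therefore expected to give about 1000000 nM, within a range from 200000 nM to 5000000 nM.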

Compound 4, solubility: 2720000 nM
Compound 4: the middle estimate sits 2.7-fold (0.43 log units) below what was measured; low and high end bracket the measured number.
By their numbers in this assay, from the lowest: compound 1; then compound 3; then compound 4; then compound 2.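

Replacing 1-hydroxy-2-((pyridin-2-yl)amino)ethyl with 2-oxo-1,3-oxazolidin-5-yl on a saturated chain carbon bound to an oxygen on an aromatic ring gives, in this assay, a 13-fold lower number from compound 2 to compound 4 (1.11 log units; beyond the scatter). Among the compounds shown here, this is the first pair here that differs in one place, and it shows that the read-out responds strongly to this exchange. No measurement here indicates which part of the exchange accounts for the step. On these data alone, whether a smaller group such as a carboxylic acid or an amine, or a longer chain, on this carbon would read nearer compound 2 or compound 4 remains open.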